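The compounds below may be only part of what the source reports. "The series", "measured", "known", "first", "only" and "open" are said of these compounds alone.

Three measured compounds share one core and differ only in the aryl group attached on an aromatic carbon. Compound 1 `Cc1ccccc1-c1cc(C)c(Nc2ccnc(Nc3ccc(C#N)cc3)n2)c(C)c1` gives 3820 nM in an ADME assay on MT4 cells (Homo sapiens) for cytotoxicity, read by MTT assay, with a stated time of 4 days; on this read-out lower numbers stand for higher toxicity in this test and higher numbers for lower toxicity in this test. Compound 2 `Cc1cc(-c2ccccc2C(F)(F)F)cc(C)c1Nc1ccnc(Nc2ccc(C#N)cc2)n1` gives 4210 nM in this assay. Compound 3 `Cc1cc(-c2cc(Cl)cc(Cl)c2)cc(C)c1Nc1ccnc(Nc2ccc(C#N)cc2)n1` gives 4290 nM in this assay. On these numbers compound 3 cannot be set apart from the others: the step of a 1.1-fold higher number from compound 1 to compound 3 (0.05 log units; within the scatter) and the step of a 1.0-fold higher number from compound 2 to compound 3 (0.01 log units; within the scatter) both fall within the scatter, as does a 1.1-fold higher number from compound 1 to compound 2 (0.04 log units; within the scatter), so the three compounds sit at one level of cytotoxicity in this assay.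

Compound 4 `Cc1ccc(-c2cc(C)c(Nc3ccnc(Nc4ccc(C#N)cc4)n3)c(C)c2)cc1` is not yet measured. It differs from compound 3 in one place: 4-methylphenyl in place of 3,5-dichlorophenyl on an aromatic carbon. The measured steps that bear on this change are the two in which the aryl group on that aromatic carbon was exchanged, a 1.1-fold higher number from compound 1 to compound 3 (0.05 log units; within the scatter) and a 1.0-fold higher number from compound 2 to compound 3 (0.01 log units; within the scatter); each stayed within the scatter, so exchanging one aryl for another at this position has so far left this assay unmoved. The same is expected here: the step of a 1.0-fold lower number from compound 3 to compound 4 (0.02 log units; within the scatter) is estimated to remain within the scatter, with no direction preferred. Compound 4 is therefore expected to give about 4100 nM in this assay, within an estimated range of 2100 nM to 8000 nM.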

Compound 4, half-maximal cytotoxic concentration: 5570 nM
Estimate against measurement, compound 4: 1.4-fold (0.13 log units) below, within the range that was stated.
By their numbers in this assay, from the lowest: compounds 1, 2, 3 and 4 (each within the scatter of the next).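

Compound 4 adds a fourth aryl group at this position in this assay, and replacing 3,5-dichlorophenyl with 4-methylphenyl, a ring bearing no halogen, gives a 1.3-fold higher number from compound 3 to compound 4 (0.11 log units; within the scatter). Replacing the 2-(trifluoromethyl)phenyl group with the same 4-methylphenyl group gives a 1.3-fold higher number from compound 2 to compound 4 (0.12 log units; within the scatter), so the aryl groups with chlorine, with fluorine and with carbon substituents alone all remain at one level of cytotoxicity. The comparison with compound 1 adds a change not seen before, the same methyl group at a different place on the aryl ring: 4-methylphenyl in place of 2-methylphenyl gives a 1.5-fold higher number from compound 1 to compound 4 (0.16 log units; within the scatter), and this too stays within the scatter, as do the steps among all four compounds.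

Going by these compounds, all four compounds carry a six-membered aromatic ring of carbon only at this position, so it remains open whether an amine, a carboxylic acid or a longer alkyl chain there would move this assay, and whether changes elsewhere on the shared core would do so. Nothing available accounts for this flat read-out across the aryl exchanges.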